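The source may hold more compounds than are shown below. What is called first, only, known or untested is meant among the compounds shown, and "the series" means these compounds.

Measured in a functional assay on cells (Platelet, Homo sapiens) for inhibition; on this read-out lower numbers stand for stronger inhibition and higher numbers for weaker inhibition:
Compound 1 `CNC(=O)c1ccc(-c2nn(Cc3ccccc3)c3ccccc23)cc1`: > 10000 nM, a limit.
Compound 2 `CCNC(=O)c1ccc(-c2nn(Cc3ccccc3)c3ccccc23)cc1`: > 10000 nM, a limit.

Among the compounds with values here, compound 2 has no number, only this limit, and the series so far stands at the limit of > 10000 nM in this assay, at which 2 of the 2 values shown sit. Compound 3 `CC(C)NC(=O)c1ccc(-c2nn(Cc3ccccc3)c3ccccc23)cc1` differs from it by methyl in place of hydrogen on a saturated chain carbon bound to an amide-type nitrogen and a saturated chain carbon, which reads as ethylcarbamoyl to isopropylcarbamoyl. Within the data shown here, the one related measured change is a step that the two limits leave unreadable from compound 1 to compound 2, also methyl in place of hydrogen on a saturated chain carbon bound to an amide-type nitrogen. It offers no size to carry over, so no readable step or direction is expected in this assay. The expected step is a step that the limit leaves unreadable from compound 2 to compound 3. The estimate for compound 3 is 15000 nM, with an expected range of 6000 nM to 40000 nM.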

Compound 3, half-maximal inhibitory concentration: > 10000 nM
Compound 3: no number, only a limit (the forecaster's own chance of this, stated with the estimate: 90%); the middle value is on the limit's open side.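

No step can be read among compound 1, compound 2 and compound 3, because all three give only a limit: the limit of > 10000 nM in this assay, at which 3 of the 3 values shown sit.

From the compounds shown here alone, how far the change from ethylcarbamoyl to isopropylcarbamoyl shifts inhibition stays open, since none of the three compounds has a measured number.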